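From compound 2 to a trifluoromethoxy analogue

The source may hold more compounds than are shown below. What is called first, only, known or untested is meant among the compounds shown, and "the series" means these compounds.

Compound 1 `CC(O)(CSc1ccc(S(F)(F)(F)(F)F)cc1)C(=O)Nc1ccc([N+](=O)[O-])c(C(F)(F)F)c1` gives 13900 nM
Compound 2 `CC(O)(CSc1ccc(S(F)(F)(F)(F)F)cc1)C(=O)Nc1ccc(S(F)(F)(F)(F)F)cc1` gives 22300 nM

In a functional assay on DU-145 cells (Homo sapiens) for antiproliferative activity, read by propidium iodide staining, with a stated time of 96 h (a higher number here means a weaker inhibitor, a lower number a stronger inhibitor), compound 2 gives 22300 nM and compound 1 gives 13900 nM so the two stand within the scatter of each other and cannot be ranked. Compound 3 `CC(O)(CSc1ccc(OC(F)(F)F)cc1)C(=O)Nc1ccc(S(F)(F)(F)(F)F)cc1` is compound 2 with a single change, a group of 5 heavy atoms (1 carbon, 1 oxygen, 3 fluorine; no ring) in place of a group of 6 heavy atoms (5 fluorine, 1 sulfur; no ring), on an aromatic carbon on an aromatic carbon of a six-membered aromatic ring of carbon only, para to a large group. The group that enters is trifluoromethoxy. Among the compounds with values here, no measured step shows what such a change does, so no shift beyond the scatter is expected in either direction, with compound 2 at 22300 nM as the starting point. The expected step of a 1.2-fold lower number from compound 2 to compound 3 (0.09 log units; within the scatter) is therefore small. In this assay compound 3 is estimated at 18000 nM with an expected range from 8000 nM to 40000 nM for the measurement.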

Compound 3, half-maximal inhibitory concentration: 12500 nM
The estimate for compound 3 lay 1.4-fold (0.16 log units) above the measured number, and the stated range covers the measured number.
By their numbers in this assay, from the lowest: compounds 3, 1 and 2 (each within the scatter of the next).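

In this assay, putting trifluoromethoxy in place of the group of 6 heavy atoms (5 fluorine, 1 sulfur), on an aromatic carbon para to a large group, gives a 1.8-fold lower number from compound 2 to compound 3 (0.25 log units; within the scatter) and so leaves the two compounds unranked. Within the data shown here, this is the first measured step at this position, and for this one pair the exchange brings no shift beyond the scatter, with the group on the other side of the amide held constant. No measurement shown bears on why the two groups read alike here.

On these data alone, whether an amine, a carboxylic acid or a nitrile at this position would move the number beyond the scatter remains open. So does whether the same exchange would read alike in the core of compound 1 , which carries a different group on the other ring.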